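From sulfonyl to sulfanyl on the shared core

This account rests on a few compounds, and the source may have more. Where it says the series, first, only, none or still open, it means among the compounds named here.

Among the compounds with values here, in a functional assay on DU-145 cells (Homo sapiens) for inhibition, read by trypan blue exclusion, with a stated time of 96 h (on this read-out higher numbers stand for weaker inhibition of growth and lower numbers for stronger inhibition of growth), compound 2 `Cc1ccc(S(=O)(=O)/C(=C/c2ccc(Oc3ccccc3)cc2)C(=O)c2ccc(Cl)cc2)cc1` gives 1000 nM, the only exact number so far. Compound 1 `CN(C)c1ccc(/C=C(/SCc2ccccc2Cl)C(=O)c2ccc(Cl)cc2)cc1` gives > 100000 nM, which is a limit and not a number. Compound 3 `O=C(/C(=C\c1ccc(Oc2ccccc2)cc1)SCc1ccccc1Cl)c1ccc(Cl)cc1` carries (2-chlorobenzyl)sulfanyl in place of (4-methylphenyl)sulfonyl on a double-bonded chain carbon bound to a carbonyl carbon and a double-bonded chain carbon. Compound 1 also carries (2-chlorobenzyl)sulfanyl and reaches the limit (the limit of > 100000 nM in this assay, at which 1 of the 2 values shown sits), so weaker growth inhibition beyond the scatter is expected. The expected change is an 8.0-fold higher number from compound 2 to compound 3 (0.90 log units; beyond the scatter). Compound 3 is estimated at 8000 nM, with an expected range of 1500 nM to 60000 nM.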

Compound 3, concentration for 50% growth inhibition: 1000 nM
Compound 3: the middle estimate sits 8.0-fold (0.90 log units) above what was measured, and the stated range ends above it.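

At the double-bonded chain carbon bound to a carbonyl carbon and a double-bonded chain carbon, (2-chlorobenzyl)sulfanyl can replace (4-methylphenyl)sulfonyl with the phenoxy group kept, showing no change at the digits printed from compound 2 to compound 3 (within the scatter). The (2-chlorobenzyl)sulfanyl group alone therefore does not account for the result of compound 1, since phenoxy in place of dimethylamino on an aromatic carbon gives an at least 100-fold lower number from compound 1 to compound 3 (2.00 log units; beyond the scatter). The value of compound 1 is a limit and not a number: the limit of > 100000 nM in this assay, at which 1 of the 3 values shown sits.

Still open, from the compounds shown here alone, is whether benzylsulfanyl without the chlorine behaves like (2-chlorobenzyl)sulfanyl. Also open, going by these compounds, is how a morpholine on that aromatic carbon would read.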